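The source may report more compounds than this note shows. Statements on the series, on what has been measured and on what is new or still open speak of the compounds shown alone.

Measured compounds:
Compound 1, `CC(=O)O[C@@H]1[C@H](OC(C)=O)[C@@H](CN=[N+]=[N-])O[C@H]1n1cnc2c(N)nc(F)nc21`, gives 18000 nM in an ADME assay on L6 cells (Rattus norvegicus) for inhibition, read by resazurin assay, with a stated time of 72 h; on this read-out higher numbers stand for weaker inhibition and lower numbers for stronger inhibition.
Compound 2, `CC(=O)O[C@@H]1[C@H](OC(C)=O)[C@@H](CN=[N+]=[N-])O[C@H]1n1cnc2c(N)nc(Cl)nc21`, gives 141000 nM in this assay.
Compound 3, `[N-]=[N+]=NC[C@H]1O[C@@H](n2cnc3c(N)nc(F)nc32)[C@H](O)[C@@H]1O`, gives 3100 nM in this assay.

Compound 4, `[N-]=[N+]=NC[C@H]1O[C@@H](n2cnc3c(N)nc(Cl)nc32)[C@H](O)[C@@H]1O`, has not yet been measured in this assay. It differs from compound 3 by chloro in place of fluoro on an aromatic carbon. The same change separates compound 1 from compound 2, namely (chloro in place of fluoro on an aromatic carbon), and there it produced a 7.8-fold higher number from compound 1 to compound 2 (0.89 log units; beyond the scatter). How the core of compound 3 differs from that of compound 1 is not broken down here; compound 3 gives the lowest number of the three. Among the measured compounds shown here, only one earlier instance of this change is known, so the expectation rests on it alone. Compound 4 is expected to show a 6.5-fold higher number from compound 3 to compound 4 (0.81 log units; beyond the scatter), because the same change gave a 7.8-fold higher number from compound 1 to compound 2 (0.89 log units; beyond the scatter). Compound 4 is thus estimated at 20000 nM, with a likely range from 5000 nM to 80000 nM.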

Compound 4, half-maximal inhibitory concentration: 155000 nM
Estimate against measurement, compound 4: 7.8-fold (0.89 log units) below, and the stated range ends below it.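

In this assay, chloro in place of fluoro on an aromatic carbon gives a 50-fold higher number from compound 3 to compound 4 (1.70 log units; beyond the scatter), and set beside the earlier step, the direction of the change holds while its size does not: the same change on two cores in this assay, a 7.8-fold higher number (0.89 log units; beyond the scatter) from compound 1 to compound 2 and a 50-fold higher number (1.70 log units; beyond the scatter) from compound 3 to compound 4, 6.4-fold (0.81 log units) apart, beyond the scatter of two such steps

The number rises on both cores, but the size of the rise found on one core did not carry over to the other. These two pairs do not show what sets the size of the step, and they give no rule for any further core.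

The compounds shown leave open how bromo or a methoxy group on the same aromatic carbon would read in this assay. They also leave open whether an amine in place of the azide would alter the step.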